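This account rests on a few compounds, and the source may have more. Where it says the series, first, only, none or still open, it means among the compounds named here.

Within the data shown here, compound 2 `COc1ccc(C(=O)/C=C/c2cc(-c3cc(OC)c(OC)c(OC)c3)n[nH]2)cc1` stands at the weaker end of the two numbers so far: in a functional assay on SK-MEL-2 cells (Homo sapiens) for cytotoxicity, read by sulforhodamine B assay, with a stated time of 48 h, tested at 10 uM (on this read-out higher numbers stand for a weaker effect at the one concentration tested and lower numbers for a stronger effect), compound 2 gives 21%, whereas compound 1 `COc1ccc(C(=O)/C=C/c2cc(-c3cc(OC)c(OC)c(OC)c3)n[nH]2)cc1OC` gives -81%. Among the measured compounds shown here, the only measured step, a number 102 percentage points higher from compound 1 to compound 2 (beyond the scatter), involved a different change on the same ring, so it bears on compound 3 `COc1cc(-c2cc(/C=C/C(=O)c3ccc(F)c(F)c3)[nH]n2)cc(OC)c1OC` only by showing that this ring matters. The change to compound 3 is 3,4-difluorophenyl in place of 4-methoxyphenyl on a carbonyl carbon. For the measured compounds named here, no step of this kind has been measured, so no direction is expected beyond the scatter; the step of a number 14 percentage points higher from compound 2 to compound 3 (beyond the scatter) is the estimate, with wide uncertainty. Compound 3 is expected to give 35%, between -40% and 95%.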

Compound 3, a percentage reported as activity, at one concentration (the size of the read-out at that concentration, not a potency): -28%
Compound 3: middle estimate off by 63 percentage points, on the high side, and the stated range covers the measured number.
By their numbers in this assay, from the lowest: compound 1; then compound 3; then compound 2.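

In this assay, replacing 4-methoxyphenyl with 3,4-difluorophenyl on the carbonyl carbon gives a number 49 percentage points lower from compound 2 to compound 3 (beyond the scatter) and shows that this position can hold a ring with no methoxy group and still give a stronger effect. Replacing 3,4-dimethoxyphenyl with the same group gives a number 53 percentage points higher from compound 1 to compound 3 (beyond the scatter) and leaves compound 1 the strongest of the three. No measurement shown here explains this order. Still open, from the compounds shown here alone, is whether one fluorine alone would do the same, and what an amine or a carboxylic acid on this ring would give.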